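The compounds below may be only part of what the source reports. "The series", "measured", "known", "first", "only" and "open" are said of these compounds alone.

Compound 1 `NCCCCCOC[C@H]1O[C@@H](OCCc2c[nH]c3ccccc23)[C@H](OCc2ccccc2)[C@@H](OCc2ccccc2)[C@@H]1OCc1ccccn1` gives 890 nM in an assay on isolated protein for binding affinity to somatostatin receptor type 4 (Homo sapiens), read by radioligand binding; on this read-out higher numbers stand for weaker inhibition and lower numbers for stronger inhibition.
Compound 2 `NCCCCCOC[C@H]1O[C@@H](OCCc2c[nH]c3ccccc23)[C@H](OCc2ccccc2)[C@@H](OCc2ccccc2)[C@@H]1OCc1cccnc1` gives 360 nM in this assay.

Within the data shown here, of the two numbers so far, compound 2 has the lower one, and the only measured step is the one leading to it: a 2.5-fold lower number from compound 1 to compound 2 (0.39 log units; beyond the scatter). Compound 3 `NCCCCCOC[C@H]1O[C@@H](OCCc2c[nH]c3ccccc23)[C@H](OCc2ccccc2)[C@@H](OCc2ccccc2)[C@@H]1OCc1ccncc1` has not yet been measured in this assay. It differs from compound 2 only in the pyridine ring: pyridin-4-yl in place of pyridin-3-yl on a saturated chain carbon bound to an oxygen on a saturated carbon. Among the measured compounds shown here, the one measured step shows that moving the nitrogen within this ring can shift the number by a modest amount, but it says nothing directly about the pyridin-4-yl arrangement, so no firm direction can be drawn from it. The estimate therefore keeps compound 3 near compound 2, with a range wide enough to cover a shift of the size seen in the measured step either way; the expected step from compound 2 to compound 3 is a 1.0-fold lower number from compound 2 to compound 3 (0.01 log units; within the scatter), and the expected value for compound 3 is 350 nM with a range from 120 nM to 1000 nM.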

Compound 3, inhibition constant: 570 nM
Beside the measured number, compound 3's estimate is 1.6-fold (0.21 log units) below it; measured number inside the range.
By their numbers in this assay, from the lowest: compounds 2, 3 and 1 (each within the scatter of the next, the first and the last beyond it).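

The pyridin-4-yl ring gives two steps, one from each earlier compound (a 1.6-fold higher number from compound 2 to compound 3 (0.20 log units; within the scatter)) and (a 1.6-fold lower number from compound 1 to compound 3 (0.19 log units; within the scatter)), so in this assay compound 3 cannot be told apart from either of the others. Only pyridin-3-yl and pyridin-2-yl remain separated beyond the scatter, which means that across all three placements of the ring nitrogen at this position, the numbers stay close together and only the two ends of the series truly differ. Nothing measured here explains these small differences.

The compounds shown leave open how this position would respond to a larger change than moving the ring nitrogen, such as a plain phenyl ring with no nitrogen, or a pyridine ring carrying an amine. They also leave open whether these small differences would hold with other groups on the shared core.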